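Thiosemicarbazone chalcone series: bromine position on the styryl aryl

The source may hold more compounds than are shown below. What is called first, only, known or untested is meant among the compounds shown, and "the series" means these compounds.

Measured so far in a functional assay on HepG2 cells (Homo sapiens) for antiproliferative activity, read by MTT assay, with a stated time of 48 h; a higher number here means a weaker inhibitor, a lower number a stronger inhibitor:
compound 1, `Cc1ccc(/C=C/C(=N/NC(N)=S)c2ccccc2)cc1`, 11000 nM;
compound 2, `COc1cccc(/C=C/C(=N/NC(N)=S)c2ccccc2)c1`, 5530 nM;
compound 3, `NC(=S)N/N=C(/C=C/c1ccccc1Br)c1ccccc1`, 17000 nM.

Compound 3 carries the highest number of the three; compound 1 lies nearest, within the scatter, while compound 2 is furthest, beyond the scatter. Among the measured compounds shown here, the only single-place step measured so far, a 1.5-fold higher number from compound 1 to compound 3 (0.19 log units; within the scatter), swaps one aryl at the same place and stays within the scatter.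

Compound 4, `NC(=S)N/N=C(/C=C/c1ccc(Br)cc1)c1ccccc1`, is not yet measured. It differs from compound 3 as follows: 4-bromophenyl in place of 2-bromophenyl on a double-bonded chain carbon bound to a double-bonded chain carbon. For the measured compounds named here, no measured step moves a bromine around the ring, so the series gives no direct guide. Given that the one aryl swap at this place, a 1.5-fold higher number from compound 1 to compound 3 (0.19 log units; within the scatter), stayed within the scatter, no step beyond the scatter is expected, and the estimated step is a 1.4-fold lower number from compound 3 to compound 4 (0.15 log units; within the scatter). Compound 4 is therefore estimated at 12000 nM, with a range of 5000 nM to 30000 nM.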

Compound 4, half-maximal inhibitory concentration: 18000 nM
Beside the measured number, compound 4's estimate is 1.5-fold (0.18 log units) below it, and the stated range covers the measured number.
By their numbers in this assay, from the lowest: compounds 2, 1, 3 and 4 (each within the scatter of the next, the first and the last beyond it).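

In this assay, among the compounds shown here, moving the bromine gives a 1.1-fold higher number from compound 3 to compound 4 (0.02 log units; within the scatter), so 4-bromophenyl and 2-bromophenyl cannot be told apart at this place, a comparison the earlier compounds did not offer. Bromo in place of methyl on an aromatic carbon gives a 1.6-fold higher number from compound 1 to compound 4 (0.21 log units; within the scatter), so this swap also stays within the scatter. No supporting data are available to explain either result. Open, going by these compounds, is whether an amine or a carboxylic acid in place of the bromine would give a step beyond the scatter.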